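Longer Amine Chains on a Shared Core

The compounds below may be only part of what the source reports. "The series", "measured", "known", "first", "only" and "open" are said of these compounds alone.

Measured in a functional assay on DU-145 cells (Homo sapiens) for antiproliferative activity, read by WST assay, with a stated time of 3 days; on this read-out higher numbers stand for weaker inhibition and lower numbers for stronger inhibition:
- Compound 1 `CCCN(CCC)CCCOc1c(-c2cc(OC)c(OC)c(OC)c2)oc2ccccc2c1=O`: > 50000 nM (a limit)
- Compound 2 `CCCN(CCC)CCCCOc1c(-c2cc(OC)c(OC)c(OC)c2)oc2ccccc2c1=O`: 35800 nM
- Compound 3 `CCCCN(CCCC)CCCCOc1c(-c2cc(OC)c(OC)c(OC)c2)oc2ccccc2c1=O`: 15300 nM

Compound 3 gives the lowest number of the three, 15300 nM. Compound 4 `CCCCCN(CCCCC)CCCOc1c(-c2cc(OC)c(OC)c(OC)c2)oc2ccccc2c1=O` is unmeasured, and it differs from compound 3 as follows: dipentylamino in place of (dibutylamino)methyl on a saturated chain carbon, three bonds along the chain from an oxygen on an aromatic ring. For the measured compounds named here, two measured steps bear on this. Dibutylamino in place of dipropylamino gave a 2.3-fold lower number from compound 2 to compound 3 (0.37 log units; beyond the scatter). (Dipropylamino)methyl in place of dipropylamino gave an at least 1.3-fold lower number from compound 1 to compound 2 (0.14 log units; that floor lies within the scatter), a floor that rests on a limit. Compound 4 continues the first swap and undoes the second, so the two are expected largely to offset each other, leaning slightly toward lower numbers. The expected change is a 1.7-fold lower number from compound 3 to compound 4 (0.23 log units; within the scatter), which is no clear step beyond the scatter. In this assay the estimate for compound 4 is 9000 nM, with an expected range of 2500 nM to 30000 nM.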

Compound 4, half-maximal inhibitory concentration: 12300 nM
Estimate against measurement, compound 4: 1.4-fold (0.14 log units) below, and the stated range covers the measured number.
By their numbers in this assay, from the lowest: compounds 4 and 3 (each within the scatter of the next); then compound 2. At a limit, above all of these: compound 1.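

Dipentylamino in place of (dibutylamino)methyl gives a 1.2-fold lower number from compound 3 to compound 4 (0.09 log units; within the scatter), so here a shorter chain to the nitrogen costs nothing clear once the amine's own chains are longer. Dipentylamino in place of (dipropylamino)methyl gives a 2.9-fold lower number from compound 2 to compound 4 (0.46 log units; beyond the scatter). With the chain to the nitrogen held fixed, dipentylamino in place of dipropylamino gives an at least 4.0-fold lower number from compound 1 to compound 4 (0.60 log units; beyond the scatter), a floor only, since compound 1 stands at a limit.

On these data alone, whether dihexylamino would continue this trend remains open. So does what a ring amine such as piperidine would do at this position.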